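The compounds below may be only part of what the source reports. "The series", "measured", "known", "first", "only" and "open" are said of these compounds alone.

Three closely related compounds have been measured in an ADME assay on liver for metabolic stability, with Liver microsome (Rattus norvegicus) as the target, read by LC-MS, using microsomes, with a stated time of 5 h; a higher number here means faster removal of the compound, a lower number slower removal. Compound 2 `O[C@H](c1ccccn1)[C@]1(c2cc(C(F)(F)F)ccn2)C[C@H](O)C1` gives 50 mL/min/kg and compound 3 `C[C@]1(O)C[C@@](c2ccnc(C(F)(F)F)c2)([C@H](O)c2ccccn2)C1` gives 50 mL/min/kg, so these two stand level, together at the low end of the three numbers. Compound 1 `O[C@H](c1ccccn1)[C@]1(c2cccc(OC(F)(F)F)c2)C[C@@H](O)C1` gives 217 mL/min/kg, a higher number than compound 2 shows, and the gap lies beyond the usual scatter of repeated measurements.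

The next compound, compound 4 `C[C@]1(O)C[C@](c2cc(C(F)(F)F)ccn2)([C@H](O)c2ccccn2)C1`, changes compound 2 in one place: methyl in place of hydrogen on a saturated ring carbon. In short, it has methyl in place of hydrogen on a saturated ring carbon. Within the data shown here, no measured pair shows this change alone, so its size in this assay cannot be read directly. Compound 3 also carries a methyl on a saturated ring carbon, although it differs from compound 2 in other ways, and compound 3 still gives 50 mL/min/kg. That is only a weak hint, but it points to no step beyond the scatter. The expected size of the step is no change at the digits printed from compound 2 to compound 4 (within the scatter). For compound 4 the estimated clearance is 50 mL/min/kg, with an expected range of 25 mL/min/kg to 100 mL/min/kg.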

Compound 4, clearance: 100 mL/min/kg
Compound 4: the middle estimate sits 2.0-fold (0.30 log units) below what was measured, and the stated range covers the measured number.
By their numbers in this assay, from the lowest: compounds 2, 3 and 4 (each within the scatter of the next); then compound 1.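

In this assay, among these compounds, the step of a 2.0-fold higher number from compound 2 to compound 4 (0.30 log units; within the scatter) gives the first direct reading of methyl in place of hydrogen on this saturated ring carbon of the four-membered ring. At this position, two ring bonds from the ring atom that bears the hydroxy(pyridin-2-yl)methyl group, the added carbon therefore produces no change that can be told apart from the variation between repeated measurements. No separate measurement helps to explain this result.

What the compounds shown leave open is how a different group on the same carbon, such as an ethyl group, a longer chain, an amine or a carboxylic acid, would read in this test. This single pair also cannot show whether the methyl would give a similar step on the core of compound 1.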